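Chloro in Place of Hydrogen: Expected Cytotoxicity of Compound 4

The compounds below may be only part of what the source reports. "The series", "measured", "known", "first", "only" and "open" are said of these compounds alone.

In an ADME assay on MDCK cells (Canis lupus familiaris) for cytotoxicity, read by MTT assay, with a stated time of 3 days (a lower number here means that less compound is tolerated, a higher number that more compound is tolerated), compound 1 `CC1(C)C[C@H](O)C[C@](C)(CNc2nc3ccccc3s2)C1` gives 36800 nM.
In this assay compound 2 `CC1(C)C[C@H](O)C[C@](C)(CNc2nc3ccc(Cl)cc3s2)C1` gives 4200 nM.
In this assay compound 3 `CC1(C)C[C@H](O)C[C@](C)(CNc2cccc(C(F)(F)F)c2)C1` gives 7800 nM.

Compound 4 `CC1(C)C[C@H](O)C[C@](C)(CNc2cc(Cl)cc(C(F)(F)F)c2)C1` has not yet been measured. It differs from compound 3 by chloro in place of hydrogen on an aromatic carbon. The same kind of change separates compound 1 from compound 2, namely (chloro in place of hydrogen on an aromatic carbon), and there it brought an 8.8-fold lower number from compound 1 to compound 2 (0.94 log units; beyond the scatter). The surroundings differ, though: in compound 2 the chloro sits on a ring that is part of a fused system, meta and para to a fused ring, whereas in compound 4 it sits meta to a trifluoromethyl group on a ring of carbon only. The difference between the two cores is not broken down here. Because the earlier change gave an 8.8-fold lower number from compound 1 to compound 2 (0.94 log units; beyond the scatter), a step of a 4.3-fold lower number from compound 3 to compound 4 (0.64 log units; beyond the scatter) is expected in this assay, though smaller, since the setting is only similar. Compound 4 is therefore estimated at 1800 nM, between 600 nM and 5500 nM.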

Compound 4, half-maximal cytotoxic concentration: 6700 nM
Estimate against measurement, compound 4: 3.7-fold (0.57 log units) below; measured number outside the range, above it.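

Chloro in place of hydrogen on an aromatic carbon gives a 1.2-fold lower number from compound 3 to compound 4 (0.07 log units; within the scatter) in this assay, so on this core the change cannot be told apart from the ordinary spread of repeated measurements. The same change therefore does not carry over with the same size from one core to the other: the same change on two cores in this assay, an 8.8-fold lower number (0.94 log units; beyond the scatter) from compound 1 to compound 2 and a 1.2-fold lower number (0.07 log units; within the scatter) from compound 3 to compound 4, 7.5-fold (0.88 log units) apart, beyond the scatter of two such steps. Within the data shown here, this rests on only two pairs, and it shows neither which feature of the cores goes with the gap nor what the change would do on a third core.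

The compounds shown leave open whether a bromo, methoxy or nitrile group on that same aromatic carbon would follow chloro. They also leave open how an amine in place of the hydroxyl on the shared core would fare.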